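A few compounds are considered here, and "the series" means these few. Any claim that something is new, unique, unknown or untested is made for them only; others in the source may bear on it.

Measured compounds:
compound 1, `COc1cc(-c2ccnc3cc(-c4ccccc4)nn23)cc(OC)c1OC`: 458 nM
compound 2, `COc1ccc(-c2cc3nccc(-c4cc(OC)c(OC)c(OC)c4)n3n2)cc1`: 373 nM
compound 3, `COc1cc(-c2ccnc3cc(-c4ccc5c(ccn5C)c4)nn23)cc(OC)c1OC`: 19 nM

In a functional assay on HeLa cells (Homo sapiens) for inhibition, read by CCK-8 assay, with a stated time of 48 h (on this read-out lower numbers stand for stronger inhibition and higher numbers for weaker inhibition), compound 3 gives the lowest number of the three; the nearest is compound 2, and compound 1 stands furthest away, both separated from compound 3 by steps beyond the scatter. Compound 4, `COc1cc(-c2ccnc3cc(-c4ccc(C(F)(F)F)cc4)nn23)cc(OC)c1OC`, has not yet been measured. It differs from compound 3 in one place: 4-(trifluoromethyl)phenyl in place of 1-methyl-1H-indol-5-yl on an aromatic carbon.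

Among the compounds with values here, two measured steps bear on this change, since both replace a plain phenyl-type group by the 1-methyl-1H-indol-5-yl group at the same position: a 24-fold lower number from compound 1 to compound 3 (1.38 log units; beyond the scatter) and a 20-fold lower number from compound 2 to compound 3 (1.29 log units; beyond the scatter). The change from compound 3 to compound 4 runs the other way, back to a six-membered carbon-only ring, so a large step toward a higher number is expected in this assay, with the 4-(trifluoromethyl)phenyl group landing near the level of compounds 1 and 2. The expected step is a 21-fold higher number from compound 3 to compound 4 (1.32 log units; beyond the scatter). Compound 4 is therefore estimated at 400 nM, within a range of 120 nM to 1500 nM.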

Compound 4, half-maximal inhibitory concentration: 1840 nM
Estimate against measurement, compound 4: 4.6-fold (0.66 log units) below; measured number outside the range, above it.
By their numbers in this assay, from the lowest: compound 3; then compounds 2 and 1 (each within the scatter of the next); then compound 4.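

In this assay, this position proves to distinguish among phenyl groups as well as between them and 1-methyl-1H-indol-5-yl, since a 97-fold higher number from compound 3 to compound 4 (1.99 log units; beyond the scatter) places the 4-(trifluoromethyl)phenyl group beyond the level of the other two phenyl-type groups. Hydrogen and methoxy on this ring had stayed within the scatter of each other, whereas trifluoromethyl gives a 4.9-fold higher number from compound 2 to compound 4 (0.69 log units; beyond the scatter) and a 4.0-fold higher number from compound 1 to compound 4 (0.60 log units; beyond the scatter) as steps beyond it, so the group carried by the phenyl ring can matter here. Nothing given here accounts for this result.

What the compounds leave open is whether a nitrile, an amine or a carboxylic acid on the same phenyl ring would stay near compound 1 or fall toward compound 4. They also leave open whether fused rings other than 1-methyl-1H-indol-5-yl, such as a quinoline, would reach the level of compound 3.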